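Notes on a nucleoside series: maximal B-cell response

The compounds below may be only part of what the source reports. "The series", "measured", "known", "first", "only" and "open" are said of these compounds alone.

Measured so far:
compound 1 `Nc1nc(O)c2c(n1)n(C1OC(CO)[C@@H](O)[C@H]1O)c(=O)n2Cc1ccc(Cl)c(Cl)c1`: 55%
compound 2 `CCCn1c(=O)n(C2CCC(COC(C)=O)O2)c2nc(NC(C)=O)nc(O)c21`: 100%

In a functional assay on the whole organism (B cells) with Mus musculus as the target (on this read-out lower numbers stand for smaller maximal responses and higher numbers for larger maximal responses), compound 1 gives 55%. Compound 2 gives 100% in this assay. Within the data shown here, of the two numbers known, compound 1 stands lowest; compound 2 lies higher by a gap that is beyond the scatter. Among the measured compounds shown here, compounds 1 and 2 differ in several places at once, so no single step between them is defined and only their two values can be set side by side.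

Compound 3 `Nc1nc(O)c2c(n1)n(C1OC(CO)[C@@H](O)[C@H]1O)c(=O)n2CC(O)CO` has not yet been measured in this assay. It derives from compound 1 by one change: 1,2-dihydroxyethyl in place of 3,4-dichlorophenyl on a saturated chain carbon bound to an aromatic nitrogen. For the measured compounds named here, whether this change moves the maximal response up, down or not at all is not told by any measured pair; the only firm anchor is compound 1 itself with 55%.

Given that absence, a moderate upward step is the expectation, with wide uncertainty, and the expected step from compound 1 to compound 3 is a number 15 percentage points higher from compound 1 to compound 3 (beyond the scatter). Compound 3 is estimated at 70%, in the range 40% to 100%.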

Compound 3, largest response reached (reported as maximal response), in percent of the reference or control that the assay uses: 136%
Compound 3: the middle estimate sits 66 percentage points below what was measured; measured number above the stated range.
By their numbers in this assay, from the lowest: compound 1; then compound 2; then compound 3.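

Working notes, position on the saturated chain carbon bound to an aromatic nitrogen: in this assay the exchange of 3,4-dichlorophenyl for 1,2-dihydroxyethyl is a step of a number 81 percentage points higher from compound 1 to compound 3 (beyond the scatter) on an otherwise unchanged core, so this one place alone is enough to shift the maximal response. Among these compounds, the earlier pair differed in several places at once and could not assign any shift to a single site; this step is the first that does so, and its direction is upward on going from the chlorinated aromatic ring to the open chain bearing hydroxyl groups. No measurement at hand explains the size or direction of this step.

The exchange removes the aromatic ring and the chlorine atoms and introduces the hydroxyl groups in a single move, so the compounds shown do not separate the contribution of each. From the compounds shown here alone, how the maximal response would run with an unsubstituted benzyl, a butyl chain, an amine or a carboxylic acid at this place remains open, as does whether the step carries over to a core bearing other changes.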